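A Small Change at the Ring Amine

The compounds below may be only part of what the source reports. "The series", "measured", "known", "first", "only" and "open" are said of these compounds alone.

Compound 1 `CCOC(=O)C1=C(C)OC(N)=C(C#N)C1c1ccc(OC2CCCC2)cc1`, compound 2 `O=C1CCCC/C1=C\c1ccc(OC2CCCC2)cc1` and compound 3 `CN1CCC(=O)/C(=C/c2ccc(OC3CCCC3)cc2)C1` were tested in a functional assay on MCF7 cells (Homo sapiens) for antiproliferative activity, read by MTT assay; a higher number here means a weaker inhibitor, a lower number a stronger inhibitor. Compound 1 gives 7500 nM, compound 2 gives 49400 nM and compound 3 gives 18100 nM. On these numbers compound 3 stands second highest of the three, nearer to compound 1 and further from compound 2, both gaps lying beyond the usual scatter. Compound 4 `CCN1CCC(=O)/C(=C/c2ccc(OC3CCCC3)cc2)C1` has not yet been measured in this assay. It differs from compound 3 by methyl in place of hydrogen on a saturated chain carbon bound to an amine nitrogen in a ring. Among the compounds with values here, no step between measured compounds is known, so the expectation rests on compound 3 alone, whose value of 18100 nM serves as the anchor. Only a small step is expected, in either direction and most likely none beyond the scatter, written as a 1.1-fold lower number from compound 3 to compound 4 (0.05 log units; within the scatter). Compound 4 is therefore expected to give 16000 nM, within a range of 7000 nM to 40000 nM.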

Compound 4, half-maximal inhibitory concentration: 13700 nM
Estimate against measurement, compound 4: 1.2-fold (0.07 log units) above; low and high end bracket the measured number.
By their numbers in this assay, from the lowest: compounds 1, 4 and 3 (each within the scatter of the next, the first and the last beyond it); then compound 2.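

Within the data shown here, at the saturated chain carbon bound to an amine nitrogen in a ring, the earlier compounds offered no step. Here, methyl in place of hydrogen gives a 1.3-fold lower number from compound 3 to compound 4 (0.12 log units; within the scatter) in this assay, so the first change read at this position, methyl to ethyl, cannot be told from repeated measurement. No evidence bears on this result.

As far as these compounds go, whether a longer chain, a benzyl group or a carboxylic acid at this position would move the number beyond the scatter remains open. So does the effect of replacing the ethyl with hydrogen on the ring amine.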